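The source may report more compounds than this note shows. Statements on the series, on what has been measured and on what is new or still open speak of the compounds shown alone.

Compound 1 `Cc1oc(-c2c(C)c(C)c(C)c(C)c2C)nc1CN1CCC(C(=O)NCCCN2C[C@H](C)C[C@H](C)C2)CC1` is the starting point for this step. In an ADME assay on Huh7.5.1 cells (Homo sapiens) for cytotoxicity, read by ATP content, with a stated time of 48 h (on this read-out higher numbers stand for lower toxicity in this test and lower numbers for higher toxicity in this test), compound 1 gives 8180 nM, the lowest of the three numbers in hand. Compound 3 `Cc1ccccc1-c1nc(CN2CCC(C(=O)NCCCN3CC4CCCC(C4)C3)CC2)c(C)o1` gives 10900 nM in this assay, a value within the scatter of that of compound 1, so the two cannot be told apart. Compound 2 `Cc1ccccc1-c1nc(CN2CCC(C(=O)NCCCN3[C@H](C)CCC[C@@H]3C)CC2)c(C)o1` gives 21300 nM in this assay, a number beyond the scatter above compound 1.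

Compound 4 `COc1cccc(C)c1-c1nc(CN2CCC(C(=O)NCCCN3C[C@H](C)C[C@H](C)C3)CC2)c(C)o1` has not yet been measured in this assay. It differs from compound 1 in one place: 2-methoxy-6-methylphenyl in place of 2,3,4,5,6-pentamethylphenyl on an aromatic carbon. The shared core carries this aryl group and is otherwise untouched.

Among the compounds with values here, the only measured step, a 2.0-fold lower number from compound 2 to compound 3 (0.29 log units; within the scatter), concerns a change far from this position, at the saturated chain carbon three bonds from the amide-type nitrogen, and it stayed within the scatter. Within the data shown here, no measured pair varies the aryl group, so nothing in hand speaks directly to the change from compound 1 to compound 4. The expectation therefore rests on the absence of any step beyond the scatter at a single position in this set, and on the tight spread of the three values.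

Compound 4 is expected to show a 1.2-fold higher number from compound 1 to compound 4 (0.09 log units; within the scatter), a change not beyond the scatter. The estimate for compound 4 in this assay is 10000 nM, with a range from 4000 nM to 25000 nM.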

Compound 4, half-maximal cytotoxic concentration: 16700 nM
Estimate against measurement, compound 4: 1.7-fold (0.22 log units) below; the range from low to high includes it.
By their numbers in this assay, from the lowest: compounds 1, 3, 4 and 2 (each within the scatter of the next, the first and the last beyond it).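

In this assay, 2-methoxy-6-methylphenyl in place of 2,3,4,5,6-pentamethylphenyl gives a 2.0-fold higher number from compound 1 to compound 4 (0.31 log units; beyond the scatter), a modest step, but the only one shown that varies this aryl group and the only one between compounds differing in one place that lies beyond the scatter. It shows that the number in this test does respond to a change at this aromatic carbon, with the shift toward lower toxicity in this test, whereas the change at the saturated chain carbon gave a 2.0-fold lower number from compound 2 to compound 3 (0.29 log units; within the scatter), which stayed within the scatter. The swap replaces a group of 11 carbon atoms with one of 8 carbon atoms and 1 oxygen atom and brings in a hydrogen-bond acceptor, but no measurement available here accounts for the shift.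

A single step cannot separate the loss of the extra methyl groups from the entry of the methoxy group, and a plain phenyl or a pyridine ring at this place would help to tell those apart. On these data alone, it also remains open whether the same aryl change would give a similar step on the amine ends of compound 2 and compound 3.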